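From compound 2 to compound 4: a carboxymethyl step

The source may report more compounds than this note shows. Statements on the series, on what has been measured and on what is new or still open speak of the compounds shown alone.

In a physicochemical assay for solubility, in phosphate buffer, with a stated time of 24 h, at pH 7.4, tested at 200 uM (on this read-out lower numbers stand for lower solubility and higher numbers for higher solubility), compound 2 `Nc1ccc2ccc(C(=O)c3ccc(F)c(O)c3)nc2c1` gives > 200000 nM, which is a limit of the assay and not a number. Compound 1 `Cc1cc(-c2ccc3ccc(C(=O)c4ccc(F)c(O)c4)nc3c2)ccc1O` gives 13000 nM, and compound 3 `COc1cc(C(=O)c2ccc3ccccc3n2)ccc1F` gives 100000 nM. Compound 2 therefore has a limit rather than a measured position among these three.

Compound 4 `O=C(O)CNc1ccc2ccc(C(=O)c3ccc(F)c(O)c3)nc2c1` carries carboxymethyl in place of hydrogen on a nitrogen on an aromatic ring, a change from amino to (carboxymethyl)amino: carboxymethyl in place of hydrogen on a nitrogen on an aromatic ring.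

For the measured compounds named here, only one measured step involves compound 2: an at least 15-fold higher number from compound 1 to compound 2 (1.18 log units; beyond the scatter). This large step, beyond the scatter, places amino where compound 1 has 4-hydroxy-3-methylphenyl on an aromatic carbon. It ends at the limit of > 200000 nM in this assay, at which 1 of the 3 values shown sits. Going by the values given here, no measured step shows what carboxymethyl does on this nitrogen, so the step from compound 1 gives only indirect guidance.

Compound 2 has no number at > 200000 nM, so any rise in this assay could not be read as a number. The expected outcome is no step beyond the scatter, with a modest fall as the only measurable direction. The estimated change is an at least 1.2-fold lower number from compound 2 to compound 4 (0.09 log units; that floor lies within the scatter). For compound 4 the expected value is 160000 nM, with an estimated range of 60000 nM to 200000 nM.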

Compound 4, solubility: > 200000 nM
Compound 4 gave a limit, no number; the forecaster's own chance of this, stated with the estimate: 55%; middle value at least 1.2-fold (0.09 log units) away from the limit.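

In this assay compound 4 gives > 200000 nM, which is a limit of the assay and not a number. The step from the free amino group to (carboxymethyl)amino cannot be read, since both of its ends are limits, and the result adds a second compound at the same ceiling: the limit of > 200000 nM in this assay, at which 2 of the 4 values shown sit.

For the compounds shown here, the one readable step is an at least 15-fold higher number from compound 1 to compound 4 (1.18 log units; beyond the scatter), with (carboxymethyl)amino in place of 4-hydroxy-3-methylphenyl on an aromatic carbon, so a substituted nitrogen at this position, which the earlier compounds did not include, also stays clear of the measurable range.

On these data alone, how far compound 2 and compound 4 lie beyond the limit remains open, and with it whether carboxymethyl on this nitrogen changes the read-out at all. Also open, as far as these compounds go, is whether a longer chain such as carboxyethyl, a chain ending in an amine, or a primary amide in place of the carboxylic acid would stay at the limit or return a number that could be compared.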